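This account rests on a few compounds, and the source may have more. Where it says the series, first, only, none or still open, it means among the compounds named here.

Measured so far in an assay on CHO cells for displacement of a labelled ligand from 5-hydroxytryptamine receptor 7 (Homo sapiens); a lower number here means a stronger inhibitor, a higher number a weaker inhibitor:

compound 1 `CCC1(CCCCN2CCN(c3cccc(Cl)c3)CC2)C(=O)Nc2cc(F)c(Cl)cc21`: 9.07 nM
compound 2 `CCC1(CCCCN2CCN(c3cccc(OC)c3)CC2)C(=O)Nc2ccccc21`: 2.55 nM
compound 3 `CCC1(CCCN2CCN(c3cccc(Cl)c3)CC2)C(=O)Nc2ccccc21`: 21 nM

Compound 2 gives the lowest number of the three and is the strongest inhibitor here; compound 1 and compound 3 both lie beyond the scatter above it. Going by the values given here, no pair among the measured compounds differs in only one place, so no single change has been measured directly.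

Compound 4 `CCC1(CCCCN2CCN(c3ccc(Cl)c(Cl)c3)CC2)C(=O)Nc2ccccc21` has not been measured. It differs from compound 2 as follows: 3,4-dichlorophenyl in place of 3-methoxyphenyl on an amine nitrogen in a ring. Among the compounds with values here, no measured pair isolates this exchange, so the direction of the step is open; a modest loss in this assay is expected rather than a gain, with a step of roughly a 2.4-fold higher number from compound 2 to compound 4 (0.37 log units; beyond the scatter) anticipated. For compound 4 the expected value in this assay is 6 nM, estimated between 2 nM and 20 nM.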

Compound 4, inhibition constant: 0.63 nM
The estimate for compound 4 lay 9.5-fold (0.98 log units) above the measured number; measured number below the stated range.
By their numbers in this assay, from the lowest: compound 4; then compound 2; then compound 1; then compound 3.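

On the amine nitrogen in the ring, 3,4-dichlorophenyl in place of 3-methoxyphenyl gives a gain in this assay (a 4.0-fold lower number from compound 2 to compound 4 (0.61 log units; beyond the scatter)). Going by these compounds alone, this is the only single change measured directly, and it shows that binding at this position does not depend on the methoxy oxygen, the one hydrogen-bond acceptor of the leaving group. Nothing at hand accounts for the gain.

As far as these compounds go, whether both chlorines are needed remains open, as 4-chlorophenyl or unsubstituted phenyl would show at this position. A pyridyl ring there is also untested in the compounds shown.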